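A few compounds are considered here, and "the series" means these few. Any claim that something is new, unique, unknown or untested is made for them only; others in the source may bear on it.

Measured compounds in a functional assay on cells (Cancer cell lines, Homo sapiens) for inhibition, read by MTT assay, with a stated time of 48 h; on this read-out lower numbers stand for stronger inhibition and higher numbers for weaker inhibition: compound 1 `O=C(/C=C/c1ccccc1)NNC(=O)c1ccc2c(c1)OCCO2` gives 550 nM; compound 2 `O=C(/C=C/c1ccccc1F)NNC(=O)c1ccc2c(c1)OCCO2` gives 4510 nM.

Compound 1 has the lowest number of the two. Its nearest neighbour is compound 2, and the step of an 8.2-fold higher number from compound 1 to compound 2 (0.91 log units; beyond the scatter) is beyond the scatter, so compound 1 stands clearly apart as the stronger inhibitor of the pair.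

The unmeasured compound 3 `O=C(/C=C/c1ccccc1[N+](=O)[O-])NNC(=O)c1ccc2c(c1)OCCO2` differs from compound 1 by nitro in place of hydrogen on an aromatic carbon. For the measured compounds named here, only one measured step bears on this change: the step from compound 1 to compound 2 also puts a group on an aromatic carbon of the same six-membered ring of carbon only, ortho to a large group, and it raised the number, meaning weaker inhibition. With a single example, the direction is more secure than the size. Going by the values given here, a weakening is therefore expected for compound 3, of roughly the size of the one step seen. The expected step is a 6.4-fold higher number from compound 1 to compound 3 (0.80 log units; beyond the scatter). Compound 3 is estimated at 3500 nM, with a range from 900 nM to 14000 nM.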

Compound 3, half-maximal inhibitory concentration: 890 nM
Beside the measured number, compound 3's estimate is 3.9-fold (0.59 log units) above it, and the stated range ends above it.
By their numbers in this assay, from the lowest: compounds 1 and 3 (each within the scatter of the next); then compound 2.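

In this assay, the step of a 1.6-fold higher number from compound 1 to compound 3 (0.21 log units; within the scatter) shows that a group on this aromatic carbon, ortho to a large group, does not by itself bring a change beyond the scatter. At the same place, the step of a 5.1-fold lower number from compound 2 to compound 3 (0.70 log units; beyond the scatter) shows that the outcome depends on which group sits there, so the weakening seen with fluoro does not carry over to nitro. Nothing available accounts for this difference between the two groups.

With only fluoro and nitro at this place, the compounds shown leave open how a chlorine, a methoxy group or an amine would fare there. They also leave open whether fluoro and nitro would give the same contrast on other carbons of the phenyl ring.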